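Compound 4: an estimate from its measured neighbours

A few compounds are considered here, and "the series" means these few. Any claim that something is new, unique, unknown or untested is made for them only; others in the source may bear on it.

Measured in a functional assay on K562 cells (Homo sapiens) for inhibition, read by trypan blue exclusion, with a stated time of 72 h; on this read-out higher numbers stand for weaker inhibition and lower numbers for stronger inhibition:
- compound 1 `Cn1c(=O)c(S(=O)(=O)c2ccc(C(=O)O)cc2)cc2cnc(Nc3ccc4[nH]ccc4c3)nc21`: 5000 nM
- compound 2 `Cn1c(=O)c(S(=O)(=O)c2ccc(F)cc2F)cc2cnc(Nc3ccc4occc4c3)nc21`: 15000 nM
- compound 3 `Cn1c(=O)c(S(=O)(=O)c2ccc(F)cc2F)cc2cnc(Nc3ccc4c(c3)CC(=O)N4)nc21`: 15000 nM

Compound 3, at 15000 nM, stands level with compound 2 , and together they hold the highest number of the three. Compound 1 gives 5000 nM, a lower number by more than the usual scatter.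

Compound 4 `Cn1c(=O)c(S(=O)(=O)c2ccc(F)cc2F)cc2cnc(NCc3ccc4[nH]ccc4c3)nc21` is related to compound 3 by one change: a group of 10 heavy atoms (9 carbon, 1 nitrogen; one five-membered aromatic ring with 1 hetero atom, one six-membered aromatic ring of carbon only) in place of a group of 10 heavy atoms (8 carbon, 1 nitrogen, 1 oxygen; one five-membered non-aromatic ring with 1 hetero atom, one six-membered aromatic ring of carbon only), on a nitrogen on an aromatic ring. The incoming group is (1H-indol-5-yl)methyl, and it sits on a nitrogen on an aromatic ring.

Among the compounds with values here, the only measured step at this nitrogen is no change at the digits printed from compound 2 to compound 3 (within the scatter), although it involves a different pair of groups. Within the data shown here, compound 1 offers only its value, since no single-place step links it to compound 3. With so little to go on, no shift beyond the scatter is expected in this assay, and the expected step is a 1.5-fold lower number from compound 3 to compound 4 (0.18 log units; within the scatter). Compound 4 is estimated at 10000 nM, with an expected range of 4000 nM to 25000 nM.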

Compound 4, half-maximal inhibitory concentration: 75000 nM
Compound 4: middle estimate off by 7.5-fold (0.88 log units), on the low side; measured number above the stated range.
By their numbers in this assay, from the lowest: compound 1; then compounds 2 and 3 (each within the scatter of the next); then compound 4.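

In this assay, the group on the nitrogen on an aromatic ring turns out to be able to move the number: with (1H-indol-5-yl)methyl entering, the result is a 5.0-fold higher number from compound 3 to compound 4 (0.70 log units; beyond the scatter) and also a 5.0-fold higher number from compound 2 to compound 4 (0.70 log units; beyond the scatter) in place of 1-benzofuran-5-yl. The earlier step at this nitrogen, no change at the digits printed from compound 2 to compound 3 (within the scatter), gave no sign of this, so the two groups in compounds 2 and 3 read alike while the group in compound 4 stands apart in the weaker direction. No measurement at hand accounts for the higher number.

The compounds shown leave open whether this higher number goes with the methyl link or with the indole ring itself. Also open, as far as these compounds go, is how a longer chain, such as 2-(1H-indol-5-yl)ethyl, or an amine on the entering group would read.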